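The compounds below may be only part of what the source reports. "The series", "measured", "known", "first", "only" and "open" are said of these compounds alone.

Working notes, measured in a functional assay on A549 cells (Homo sapiens) for antiproliferative activity, read by MTT assay, with a stated time of 48 h; on this read-out higher numbers stand for weaker inhibition and lower numbers for stronger inhibition:
- Compound 1 `CC(C)=CCC[C@]1(C)/C=C/[C@@H](OC(=O)C=C(C)C)[C@](C)(O)/C=C/C(=O)/C(C(=O)O)=C\C1`: > 10000 nM, a limit.
- Compound 2 `CCN(CC)C/C1=C/C[C@](C)(CCC=C(C)C)/C=C/[C@@H](OC(=O)C=C(C)C)[C@](C)(O)/C=C/C1=O`: 130 nM.
- Compound 3 `CC(C)=CCC[C@]1(C)/C=C/[C@@H](OC(=O)C=C(C)C)[C@](C)(O)/C=C/C(=O)/C(Cn2cc(CO)nn2)=C\C1`: 3470 nM.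

Compound 3 holds the higher of the two actual numbers, with a 27-fold higher number from compound 2 to compound 3 (1.43 log units; beyond the scatter). Next is compound 4 `CCN(CC)C(=O)/C1=C/C[C@](C)(CCC=C(C)C)/C=C/[C@@H](OC(=O)C=C(C)C)[C@](C)(O)/C=C/C1=O`, with the change diethylcarbamoyl in place of (4-(hydroxymethyl)-1H-1,2,3-triazol-1-yl)methyl on a double-bonded ring carbon.

Three measured steps change the group at this ring carbon: an at least 76-fold lower number from compound 1 to compound 2 (1.88 log units; beyond the scatter), large; an at least 2.8-fold lower number from compound 1 to compound 3 (0.45 log units; beyond the scatter), at least modest; and the large step already given. Among the compounds with values here, compound 4 retains the two ethyl groups of compound 2, but no measured step tests a carbonyl here. A modest step towards a lower number is therefore expected, estimated as a 2.3-fold lower number from compound 3 to compound 4 (0.36 log units; beyond the scatter). For compound 4 the expected value is 1500 nM, with an estimated range of 300 nM to 7000 nM.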

Compound 4, half-maximal inhibitory concentration: 11300 nM
For compound 4 the middle estimate is 7.5-fold (0.88 log units) below the measured one, and the stated range ends below it.
By their numbers in this assay, from the lowest: compound 2; then compound 3; then compound 4.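

In this assay, the diethylcarbamoyl group of compound 4 keeps both ethyl groups of compound 2, yet the change gives an 87-fold higher number from compound 2 to compound 4 (1.94 log units; beyond the scatter), so the ethyl groups alone do not give the low number at this ring carbon. Replacing the (4-(hydroxymethyl)-1H-1,2,3-triazol-1-yl)methyl group gives a 3.3-fold higher number from compound 3 to compound 4 (0.51 log units; beyond the scatter), so here the amide also stands above the triazole. Compound 1 carries a limit, and its step to compound 4 cannot be read: the limit of > 10000 nM in this assay, at which 1 of the 4 values shown sits.

Still open, as far as these compounds go, is whether a cyclic amine, such as piperidin-1-ylmethyl or morpholin-4-ylmethyl, at this ring carbon would match compound 2.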